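From Cyano to Methoxy on a Shared Core

A few compounds are considered here, and "the series" means these few. Any claim that something is new, unique, unknown or untested is made for them only; others in the source may bear on it.

Of the compounds shown here, three sharing one core have been measured in a functional assay on U-937 cells (Homo sapiens) for antiproliferative activity, read by CCK-8 assay, with a stated time of 72 h; a lower number here means a stronger inhibitor, a higher number a weaker inhibitor. Compound 1 `Cc1cc(Nc2cc(N3CCN(C)CC3)nc(Nc3ccc(S(N)(=O)=O)cc3)n2)n[nH]1` gives 100 nM, compound 2 `Cc1cc(Nc2cc(N3CCN(C)CC3)nc(Nc3cccc(Cl)c3)n2)n[nH]1` gives 21.7 nM, and compound 3 `Cc1cc(Nc2cc(N3CCN(C)CC3)nc(Nc3ccc(C#N)cc3)n2)n[nH]1` gives 9.03 nM, the lowest of the three numbers.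

Compound 4 `COc1ccc(Nc2nc(Nc3cc(C)[nH]n3)cc(N3CCN(C)CC3)n2)cc1` keeps everything in compound 3 except one group, with methoxy in place of cyano on an aromatic carbon, para to a large group: methoxy in place of cyano on an aromatic carbon.

For the measured compounds named here, three measured steps bear on this change, and each lies beyond the scatter. The largest, an 11-fold lower number from compound 1 to compound 3 (1.04 log units; beyond the scatter), came with cyano in place of sulfamoyl. A smaller one, a 2.4-fold lower number from compound 2 to compound 3 (0.38 log units; beyond the scatter), came with 4-cyanophenyl in place of 3-chlorophenyl, and a 4.6-fold lower number from compound 1 to compound 2 (0.66 log units; beyond the scatter) came with 3-chlorophenyl in place of 4-sulfamoylphenyl. Changes to this phenyl group have therefore moved the number in all three pairs, but no measured compound carries methoxy, so the direction remains an inference. With compound 3 the lowest at 9.03 nM, a modest rise in this assay seems more likely than a further fall. The expected change is a 2.8-fold higher number from compound 3 to compound 4 (0.44 log units; beyond the scatter). Compound 4 is estimated at 25 nM, with an expected range from 8 nM to 80 nM.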

Compound 4, half-maximal inhibitory concentration: 92.3 nM
For compound 4 the middle estimate is 3.7-fold (0.57 log units) below the measured one; measured number above the stated range.
By their numbers in this assay, from the lowest: compound 3; then compound 2; then compounds 4 and 1 (each within the scatter of the next).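

At this position, para to a large group, methoxy in place of cyano in this assay gives a 10-fold higher number from compound 3 to compound 4 (1.01 log units; beyond the scatter), so an exchange between two groups with the same count of heavy atoms and hydrogen-bond acceptors is enough to produce a large step. Replacing 3-chlorophenyl with 4-methoxyphenyl gives a 4.3-fold higher number from compound 2 to compound 4 (0.63 log units; beyond the scatter), while methoxy in place of sulfamoyl gives a 1.1-fold lower number from compound 1 to compound 4 (0.03 log units; within the scatter), which shows that the lowest number does not extend to every group at this position and that, of the three groups compared here, only cyano gives it. No evidence is available to explain these differences.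

The compounds shown leave open whether another group at this position, such as an amide, a carboxylic acid or trifluoromethyl, would match compound 3 at 9.03 nM or would instead give a higher number. From the compounds shown here alone, since all four compounds keep the rest of the shared core unchanged, it also remains open whether methoxy in place of cyano would produce a step of similar size on a different core or in a different cell line.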